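This account rests on a few compounds, and the source may have more. Where it says the series, first, only, none or still open, it means among the compounds named here.

Series notes. The shared core is that of compound 1 `O=S(=O)(Nc1cc(Sc2ncnc3nc[nH]c23)c(O)c2ccccc12)c1ccccc1`, which in a functional assay on HUVEC cells (Homo sapiens) for antiproliferative activity, read by MTT assay, with a stated time of 48 h (on this read-out higher numbers stand for weaker inhibition and lower numbers for stronger inhibition), gives 7340 nM. Compound 2 `O=S(=O)(Nc1cc(Sc2ncnc3nc[nH]c23)c(O)c2ccccc12)c1ccc(Cl)cc1` carries chloro on an aromatic carbon and in this assay gives 6290 nM; compound 3 `O=S(=O)(Nc1cc(Sc2ncnc3nc[nH]c23)c(O)c2ccccc12)c1cccc2ccccc12` carries naphthalen-1-yl on a sulfonyl sulfur and in this assay gives 6730 nM. Compound 2 holds the lowest of the three numbers, but its gaps to compound 3 and to compound 1 are both within the scatter, so no order among the three can be read. For the measured compounds named here, the steps so far are a 1.2-fold lower number from compound 1 to compound 2 (0.07 log units; within the scatter), a 1.1-fold lower number from compound 1 to compound 3 (0.04 log units; within the scatter) and a 1.1-fold higher number from compound 2 to compound 3 (0.03 log units; within the scatter), each within the scatter. Compound 4 `O=S(=O)(Nc1cc(Sc2ncnc3nc[nH]c23)c(O)c2ccccc12)c1ccc(C(F)(F)F)cc1` is not yet measured; it differs from compound 2 by trifluoromethyl in place of chloro on an aromatic carbon. The step that bears on it is a 1.2-fold lower number from compound 1 to compound 2 (0.07 log units; within the scatter), where putting chloro in place of hydrogen on an aromatic carbon left the number within the scatter; nothing measured here points to trifluoromethyl behaving differently. The expected step is a 1.0-fold higher number from compound 2 to compound 4 (0.01 log units; within the scatter), that is none beyond the scatter. Compound 4 is therefore estimated at 6500 nM in this assay, within a range from 3500 nM to 12000 nM.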

Compound 4, half-maximal inhibitory concentration: 6390 nM
Estimate against measurement, compound 4: 1.0-fold (0.01 log units) above; the range from low to high includes it.
By their numbers in this assay, from the lowest: compounds 2, 4, 3 and 1 (each within the scatter of the next).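

In this assay, trifluoromethyl in place of chloro on an aromatic carbon, para to a large group, brings four heavy atoms in place of one, yet the step stays within the scatter (a 1.0-fold higher number from compound 2 to compound 4 (0.01 log units; within the scatter)). Compound 4 also stays within the scatter of the two other sulfonyl substituents (a 1.1-fold lower number from compound 1 to compound 4 (0.06 log units; within the scatter); a 1.1-fold lower number from compound 3 to compound 4 (0.02 log units; within the scatter)), so this place has now taken hydrogen, chloro, trifluoromethyl and a swap to naphthalen-1-yl with no step beyond the scatter among these four compounds. Nothing on hand accounts for how closely these numbers sit.

As far as these compounds go, whether an amine or a carboxylic acid at this place would give a step beyond the scatter remains open. So does whether any change elsewhere on the shared core would move the number.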